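Heptyloxy in place of hydroxy on the anilide ring

The source may report more compounds than this note shows. Statements on the series, on what has been measured and on what is new or still open speak of the compounds shown alone.

Three amides have been measured in an assay on microsomes from intestine for inhibition of acyl-CoA:cholesterol acyltransferase (Oryctolagus cuniculus); a lower number here means a stronger inhibitor, a higher number a weaker inhibitor. Compound 1 `CCCCCCCC/C=C/CCCCCCCC(=O)Nc1ccccc1CC` gives 1200 nM. Compound 2 `CCCCCCCCCCC1(C(=O)Nc2c(OC)cc(OC)cc2OC)CCCC1` gives 32 nM, the lowest number of the three. Compound 3 `CCCCCCCCCCC(C)(C)C(=O)Nc1c(O)cc(OC)cc1OC` gives 590 nM, the second highest number: compound 1 sits nearest to it, with a higher number that lies beyond the scatter, while compound 2 lies furthest away, with a number well below that of compound 3.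

Compound 4 `CCCCCCCCCCC(C)(C)C(=O)Nc1c(OC)cc(OC)cc1OCCCCCCC` has not yet been measured in this assay. It differs from compound 3 by one change, (heptyl in place of hydrogen on an oxygen on an aromatic ring), so that the hydroxy of compound 3 becomes heptyloxy. Within the data shown here, no measured pair shows this change, so its size is uncertain. Compound 2, which carries an alkylated oxygen at every ring position, gives 32 nM in this assay, a far lower number than compound 3; on that basis a step to a lower number, beyond the scatter, is expected from compound 3 to compound 4, namely a 3.9-fold lower number from compound 3 to compound 4 (0.59 log units; beyond the scatter). Compound 4 is therefore estimated at 150 nM in this assay, with a range from 40 nM to 600 nM.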

Compound 4, half-maximal inhibitory concentration: 140 nM
Beside the measured number, compound 4's estimate is 1.1-fold (0.03 log units) above it, and the stated range covers the measured number.
By their numbers in this assay, from the lowest: compound 2; then compound 4; then compound 3; then compound 1.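

Among these compounds, compound 3 and compound 4 form the first measured pair that differ only at this oxygen on an aromatic ring. In this assay the change from hydroxy to heptyloxy gives a 4.2-fold lower number from compound 3 to compound 4 (0.62 log units; beyond the scatter) and so shows that this position accepts a heptyl in place of hydrogen, and that the hydrogen of the hydroxy is not needed for the lower number. Nothing available separates the part played by losing that hydrogen from the part played by the heptyl chain itself.

From the compounds shown here alone, the pair gives one chain length at one position, so the trend with chain length remains unknown. Going by these compounds, it remains open how this assay would respond to methoxy, to a longer chain such as decyloxy, or to a heptyl chain ending in an amine or a carboxylic acid at this oxygen.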